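Trimming the Triol Side Chain of Compound 2

The source may hold more compounds than are shown below. What is called first, only, known or untested is meant among the compounds shown, and "the series" means these compounds.

Measured so far in a functional assay on MCF7 cells (Homo sapiens) for antiproliferative activity, read by MTT assay, with a stated time of 72 h; a higher number here means a weaker inhibitor, a lower number a stronger inhibitor:
compound 1, `COCn1c(CC(O)(CO)CO)cc(=O)[nH]c1=O`: > 100000 nM, a limit of the assay
compound 2, `C[Si](C)(C)CCOCn1c(CC(O)(CO)CO)cc(=O)[nH]c1=O`: > 100000 nM, a limit of the assay

Compound 2 stands at the upper limit of this assay, and it does so together with its companion: the limit of > 100000 nM in this assay, at which 2 of the 2 values shown sit. For the measured compounds named here, the only measured step, a step that the two limits leave unreadable from compound 1 to compound 2, runs between two limits and so cannot be read in size or direction.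

Compound 3, `C[Si](C)(C)CCOCn1c(CC(O)CO)cc(=O)[nH]c1=O`, differs from compound 2 by hydrogen in place of hydroxymethyl on a saturated chain carbon bound to an oxygen on a saturated carbon and two saturated chain carbons. Going by the values given here, no measured step touches this part of the molecule, and the one step that exists, a step that the two limits leave unreadable from compound 1 to compound 2, is itself unreadable, so there is no measured basis for expecting a shift of any size in this assay.

Compound 3 is therefore estimated at 150000 nM, in the range 40000 nM to 600000 nM, most likely reported again only as a limit. The expected step that the limit leaves unreadable from compound 2 to compound 3 is accordingly no change beyond the scatter.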

Compound 3, half-maximal inhibitory concentration: > 100000 nM
Compound 3: only a limit was reported; the forecaster's own chance of this, stated with the estimate: 85%; the middle value lies beyond the limit too.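

In this assay compound 3 gives > 100000 nM and this is only a limit. Compound 2 also stands at a limit, so no step between the two can be read in size or direction: the limit of > 100000 nM in this assay, at which 3 of the 3 values shown sit.

The compounds shown leave open whether removing the hydroxymethyl changes activity at all, since none of compound 1, compound 2 or compound 3 gives a measured potency.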